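Swapping methyl for fluoro on an aromatic ring

This account rests on a few compounds, and the source may have more. Where it says the series, first, only, none or still open, it means among the compounds named here.

Values measured in a functional assay on HeLa cells (Homo sapiens) for antiproliferative activity, read by MTT assay, with a stated time of 24 h; on this read-out lower numbers stand for stronger inhibition and higher numbers for weaker inhibition:
- compound 1 `Cc1ccc(-c2nn(-c3ccccc3)cc2-c2nc3ccccc3n2S(=O)(=O)c2ccccc2)cc1` gives 820 nM
- compound 2 `Cc1ccc(-c2nn(-c3ccccc3)cc2-c2nc3ccccc3n2S(=O)(=O)c2ccc(C)cc2)cc1` gives 480 nM
- compound 3 `Cc1ccc(-c2nn(-c3ccccc3)cc2-c2nc3ccccc3n2S(=O)(=O)c2ccc(Br)cc2)cc1` gives 2340 nM

Compound 1 holds the second highest of these three numbers. Its nearest neighbour shows a 1.7-fold lower number from compound 1 to compound 2 (0.23 log units; within the scatter), while its furthest shows a 2.9-fold higher number from compound 1 to compound 3 (0.46 log units; beyond the scatter).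

Compound 4 `O=S(=O)(c1ccccc1)n1c(-c2cn(-c3ccccc3)nc2-c2ccc(F)cc2)nc2ccccc21` has not yet been measured. It keeps the rest of compound 1 but turns the 4-methylphenyl group into a 4-fluorophenyl group: fluoro in place of methyl on an aromatic carbon. Among the compounds with values here, no measured step touches this group, since all three changes lie in a different part of the molecule, so they serve only as indirect guides. The closest in kind is another halogen replacing methyl, which gave a 4.9-fold higher number from compound 2 to compound 3 (0.69 log units; beyond the scatter). Fluoro is not bromo, however, and that step may not carry over in size. A small upward step is therefore expected in this assay, estimated as a 1.3-fold higher number from compound 1 to compound 4 (0.13 log units; within the scatter). Compound 4 is expected to give about 1100 nM. The estimated range for compound 4 runs from 400 nM to 3000 nM.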

Compound 4, half-maximal inhibitory concentration: 680 nM
Estimate against measurement, compound 4: 1.6-fold (0.21 log units) above, and the stated range covers the measured number.
By their numbers in this assay, from the lowest: compounds 2, 4 and 1 (each within the scatter of the next); then compound 3.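

In this assay, within the data shown here, the first reading at this position shows that fluoro can stand in place of methyl while the two values stay within the scatter of each other (a 1.2-fold lower number from compound 1 to compound 4 (0.08 log units; within the scatter)). The earlier steps shown here all lay in a different part of the molecule, and the halogen step among them was clearly larger (a 4.9-fold higher number from compound 2 to compound 3 (0.69 log units; beyond the scatter)), so that result did not carry over in size to this swap of 4-methylphenyl to 4-fluorophenyl. Nothing measured here accounts for why this change leaves the number within the scatter.

Going by these compounds, with only methyl and fluoro seen at this position, it remains open whether a clearly different group, such as an amine, a carboxylic acid or a longer chain, would shift the number beyond the scatter. On these data alone, it is also open whether fluoro here would behave the same way on the core of compound 2 or compound 3.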